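Swapping Methoxy for Trifluoromethyl on the Outer Ring

This account rests on a few compounds, and the source may have more. Where it says the series, first, only, none or still open, it means among the compounds named here.

Measured compounds:
Compound 1, `C#CCNC1CCc2c(SCCc3cccc(C(F)(F)F)c3)cccc21`, gives 280 nM
Compound 2, `C#CCNC1CCc2c(SCCc3cccc(OC)c3)cccc21`, gives 3820 nM
Compound 3, `C#CCNC1CCc2c(SCCc3ccc(OC)cc3)cccc21`, gives 4590 nM

All three were tested in an ADME assay on isolated protein for inhibition of Amine oxidase [flavin-containing] B (Homo sapiens); on this read-out higher numbers stand for weaker inhibition and lower numbers for stronger inhibition. They share one core and differ only in the group carried by the outer phenyl ring and in where that group sits. Compound 2 and compound 3 carry the same atoms joined differently: 4-methoxyphenyl in place of 3-methoxyphenyl on a saturated chain carbon, two bonds along the chain from a sulfur. Their numbers in this assay are close, as a 1.2-fold higher number from compound 2 to compound 3 (0.08 log units; within the scatter) shows, so no order between them can be claimed.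

The larger effect comes from the group itself. Going from compound 2 to compound 1, (trifluoromethyl in place of methoxy on an aromatic carbon), and the result is a 14-fold lower number from compound 2 to compound 1 (1.13 log units; beyond the scatter).

Compound 4, `C#CCNC1CCc2c(SCCc3ccc(C(F)(F)F)cc3)cccc21`, has not yet been measured. It relates to compound 3 as compound 1 relates to compound 2: trifluoromethyl in place of methoxy on an aromatic carbon. This is the same kind of change, but not the same one, since in compound 1 the trifluoromethyl is meta to a large group while in compound 4 it is para to a large group. Among the compounds with values here, only one earlier instance exists, so the expectation rests on that single step.

A step of similar direction is expected from compound 3 to compound 4, a 10-fold lower number from compound 3 to compound 4 (1.00 log units; beyond the scatter), because a 14-fold lower number from compound 2 to compound 1 (1.13 log units; beyond the scatter) was large, with some allowance for the different place. In this assay compound 4 is expected to give about 460 nM, between 150 nM and 1500 nM.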

Compound 4, half-maximal inhibitory concentration: 8780 nM
The estimate for compound 4 lay 19-fold (1.28 log units) below the measured number; measured number outside the range, above it.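

In this assay, trifluoromethyl in place of methoxy does not behave as one transferable step, and the two instances clearly disagree: the same change on two cores in this assay, a 14-fold lower number (1.13 log units; beyond the scatter) from compound 2 to compound 1 and a 1.9-fold higher number (0.28 log units; within the scatter) from compound 3 to compound 4, 26-fold (1.42 log units) apart, beyond the scatter of two such steps With the group para to a large group, the change gives a 1.9-fold higher number from compound 3 to compound 4 (0.28 log units; within the scatter), so this pair shows no measurable effect of the swap, and the large step seen on the other core cannot simply be added to a related compound in this series. What this does not show is why the two results part, or that the swap would fail wherever else it is tried, since two pairs show only that the outcome depends on the core carrying the change, without identifying a mechanism.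

From the compounds shown here alone, it remains open how other groups on the outer phenyl ring, such as a chlorine atom, an amine or a carboxylic acid, would compare with methoxy and trifluoromethyl at each of these two places. Going by these compounds, it is also open whether either step would hold up with a longer chain joining the sulfur to that ring, or with a second substituent added to it.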